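A Methoxy for a Methyl on the Aryl Ketone

A few compounds are considered here, and "the series" means these few. Any claim that something is new, unique, unknown or untested is made for them only; others in the source may bear on it.

Two compounds share a core carrying a hydroxamic acid and an aryl ketone. Compound 1 `Cn1cc(/C=C/C(=O)c2cccc(Cl)c2)cc1/C=C/C(=O)NO` gives 31400 nM in an assay on isolated protein for inhibition of histone deacetylase HD1B (Zea mays); a higher number here means a weaker inhibitor, a lower number a stronger inhibitor. Compound 2 `Cc1cccc(C(=O)/C=C/c2cc(/C=C/C(=O)NO)n(C)c2)c1` gives 2500 nM in this assay, the lowest of the two numbers, and the step of a 13-fold lower number from compound 1 to compound 2 (1.10 log units; beyond the scatter) shows how much the group on that ring can matter. Compound 3 `COc1cccc(C(=O)/C=C/c2cc(/C=C/C(=O)NO)n(C)c2)c1` is not yet measured; it differs from compound 2 in one place: methoxy in place of methyl on an aromatic carbon. Going by the values given here, no measured step swaps a methyl for a methoxy, so the only guidance is that a change at this position shifted the number strongly once. The direction of that earlier step need not transfer to methoxy. The expected step of a 1.2-fold higher number from compound 2 to compound 3 (0.08 log units; within the scatter) is set near zero, with a wide range. Compound 3 is therefore expected to give about 3000 nM in this assay, between 800 nM and 12000 nM.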

Compound 3, half-maximal inhibitory concentration: 600 nM
For compound 3 the middle estimate is 5.0-fold (0.70 log units) above the measured one, and the stated range ends above it.
By their numbers in this assay, from the lowest: compound 3; then compound 2; then compound 1.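

In this assay, going by these compounds alone, the position proves more responsive than the single step from chloro to methyl could show: the change to methoxy gives a 4.2-fold lower number from compound 2 to compound 3 (0.62 log units; beyond the scatter) and extends the series further, with a 52-fold lower number from compound 1 to compound 3 (1.72 log units; beyond the scatter) across the whole set. The earlier compounds shown here showed only that methyl gave a lower number than chloro, whereas the order now runs methoxy, methyl, chloro, so a group adding an oxygen and one hydrogen-bond acceptor on this aromatic carbon gives the lowest number of the three. No measurement shown here explains why the number falls with this change.

The compounds shown leave open whether the oxygen or the extra heavy atom matters for this result. They also leave open how an ethoxy group, an amine or a carboxylic acid in the same place would compare.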